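The source may report more compounds than this note shows. Statements on the series, on what has been measured and on what is new or still open speak of the compounds shown alone.

- compound 1 `CCOC(=O)C1=CCCCC1S(=O)(=O)Cc1cc(Cl)ccc1F`: 23 nM
- compound 2 `CCOC(=O)C1=CCCCC1S(=O)(=O)Cc1cc2ccccc2o1`: 134 nM
- compound 3 `COC(=O)C1=CCCCC1S(=O)(=O)Cc1ccc(F)cc1Cl`: 99 nM

All values come from a functional assay on RAW264.7 cells (Mus musculus), read by fluorescence; a lower number here means a stronger inhibitor, a higher number a weaker inhibitor. Compound 3 gives 99 nM, which lies within the scatter of compound 2 at 134 nM. Compound 1 at 23 nM has a lower number than compound 3, and that gap is beyond the scatter.

Compound 4 `CC(C)OC(=O)C1=CCCCC1S(=O)(=O)Cc1ccc(F)cc1Cl` departs from compound 3 by one change: isopropyl in place of methyl on an oxygen next to a carbonyl group. Going by the values given here, the measured compounds differ from each other in more than one place, so no measured step isolates this change. Compound 1 at 23 nM gives only a weak hint that the change could lower the number in this assay. The expected 1.4-fold lower number from compound 3 to compound 4 (0.15 log units; within the scatter) is small and toward a lower number, and it may well stay within the scatter. For compound 4 the estimated value is 70 nM, with an expected range of 25 nM to 200 nM.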

Compound 4, half-maximal inhibitory concentration: 100 nM
Estimate against measurement, compound 4: 1.4-fold (0.15 log units) below; the range from low to high includes it.
By their numbers in this assay, from the lowest: compound 1; then compounds 3, 4 and 2 (each within the scatter of the next).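

In this assay, isopropyl in place of methyl on an oxygen next to a carbonyl group gives a 1.0-fold higher number from compound 3 to compound 4 (0.00 log units; within the scatter). Going by these compounds alone, this is the first pair that differs in one place only, and it shows that, with the rest of compound 3 held fixed, methoxycarbonyl and isopropoxycarbonyl cannot be told apart in this read-out. The larger group at this position therefore costs nothing measurable here, and nothing at hand bears on the reason for this result.

From the compounds shown here alone, whether the same flat reading holds on the other side chains, those of compound 1 and compound 2, stays open. Also open, going by these compounds, is how this position reads with a longer chain such as n-butyl on the oxygen, or with a carboxylic acid or an amide in place of the ester.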